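This account rests on a few compounds, and the source may have more. Where it says the series, first, only, none or still open, it means among the compounds named here.

Going by the values given here, in a functional assay on G-361 cells (Homo sapiens) for cytotoxicity, read by MTT assay, with a stated time of 3 days (a lower number here means a stronger inhibitor, a higher number a weaker inhibitor), compound 1 (`N#Cc1c(NC(N)=S)nc(SCc2nc3ccccc3[nH]2)nc1-c1ccccc1`) gives 5.81 nM and compound 2 (`CN1CCN(c2nc(SCc3nc4ccccc4[nH]3)nc(-c3ccccc3)c2C#N)CC1`) gives 14.7 nM, so compound 2 holds the higher of the two numbers so far. Compound 3 (`N#Cc1c(-c2ccccc2)nc(SCc2nc3ccccc3[nH]2)nc1N1CCN(S(=O)(=O)c2ccccc2[N+](=O)[O-])CC1`) carries (2-nitrophenyl)sulfonyl in place of methyl on an amine nitrogen in a ring. Among the compounds with values here, only one measured step bears on this change, and only indirectly: a 2.5-fold higher number from compound 1 to compound 2 (0.40 log units; beyond the scatter) is modest and accompanies an exchange of the whole group on the aromatic carbon. Within the data shown here, no measured compound varies the group on the ring nitrogen, so the direction remains poorly defined. A modest rise in this assay is expected, with a wide margin on either side. The expected step is a 1.7-fold higher number from compound 2 to compound 3 (0.23 log units; within the scatter). For compound 3 the estimated value is 25 nM, within an expected range of 5 nM to 120 nM.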

Compound 3, half-maximal inhibitory concentration: 9.6 nM
Compound 3: the middle estimate sits 2.6-fold (0.42 log units) above what was measured; the range from low to high includes it.
By their numbers in this assay, from the lowest: compounds 1, 3 and 2 (each within the scatter of the next, the first and the last beyond it).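

Going by these compounds alone, exchanging methyl for (2-nitrophenyl)sulfonyl on the amine nitrogen in a ring gives a 1.5-fold lower number from compound 2 to compound 3 (0.19 log units; within the scatter) in this assay, the first direct reading at this position. A group of 12 heavy atoms, with a six-membered aromatic ring and 4 hydrogen-bond acceptors, thus stands in place of a single carbon without a step beyond the scatter. Nothing available explains this result.

This single pair does not show whether the position stays as permissive across other groups, such as a plain phenylsulfonyl without the nitro group, a benzoyl or an acetyl. Also open, going by these compounds, is how the same ring behaves with only a hydrogen on that nitrogen, the free secondary amine.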